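This account rests on a few compounds, and the source may have more. Where it says the series, first, only, none or still open, it means among the compounds named here.

Compound 2 `O=C(CN1CCC(c2cccc[n+]2[O-])CC1)Nc1ccc(F)cc1F` is one of three compounds whose numbers are known in a functional assay on HEK293 cells for agonist activity at D(4) dopamine receptor (Homo sapiens), read by FLIPR; on this read-out higher numbers stand for larger maximal responses and lower numbers for smaller maximal responses. In this assay compound 2 gives 74%, the highest of the three numbers shown, although compound 1 `N#Cc1cccc(C(=O)NCN2CCC(c3cccc[n+]3[O-])CC2)c1`, which gives 69% in this assay, lies within the usual scatter of it, so no order between those two can be claimed. The gap to compound 3 `CC(C)Oc1cccc(NC(=O)CN2CCC(c3cccc[n+]3[O-])CC2)c1` is another matter: in this assay compound 3 gives 48%, and that difference lies beyond the scatter.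

Compound 4 `Cc1ccc(Cl)cc1NC(=O)CN1CCC(c2cccc[n+]2[O-])CC1` has not yet been measured. It differs from compound 2 in one place: 5-chloro-2-methylphenyl in place of 2,4-difluorophenyl on an amide-type nitrogen. Going by the values given here, no step of this kind between two measured compounds exists in the set, so its size has to be guessed from what the three numbers show. Among the compounds with values here, compound 3, the only other compound with a substituted phenyl on the amide-type nitrogen, gives 48% in this assay, and that is the one sign that such a change can lower the response. Compound 4 is therefore expected to stand somewhat below compound 2, a step of about a number 14 percentage points lower from compound 2 to compound 4 (beyond the scatter), though perhaps no further than the scatter. The estimate for compound 4 in this assay is 60%, with a range from 42% to 78%.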

Compound 4, largest response reached (reported as efficacy), in percent of the reference or control that the assay uses: 58%
For compound 4 the middle estimate is 2 percentage points above the measured one; low and high end bracket the measured number.
By their numbers in this assay, from the lowest: compounds 3 and 4 (each within the scatter of the next); then compounds 1 and 2 (each within the scatter of the next).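

Going by these compounds alone, replacing 2,4-difluorophenyl with 5-chloro-2-methylphenyl on an amide-type nitrogen gives, in this assay, a number 16 percentage points lower from compound 2 to compound 4 (beyond the scatter), the first step in the set that isolates this position and shows that the group there can shift the maximal response beyond the scatter. The two groups match in every count given, with 8 heavy atoms, one six-membered aromatic ring of carbon only, no hydrogen-bond donors or acceptors and no net charge, so these counts do not tell them apart even though the response differs. Nothing measured on these compounds bears on why the response changes with this swap.

On these data alone, whether the chlorine, the methyl or the loss of the two fluorines carries the step remains open, and a plain phenyl or a phenyl bearing chlorine alone would begin to separate these contributions. Also open, as far as these compounds go, is how a pyridyl group, or a phenyl carrying an amine or a carboxylic acid, would behave on this nitrogen, and whether the same swap would give a step of similar size on another core.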